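The compounds below may be only part of what the source reports. "The series", "measured", "known", "first", "only" and "open" are said of these compounds alone.

Measured so far:
compound 1, `CC1=CC[C@H](C(C)(C)NC(=S)N/N=C/c2ccccc2)CC1`, 5700 nM;
compound 2, `CC1=CC[C@H](C(C)(C)NC(=S)N/N=C/c2ccccc2Cl)CC1`, 700 nM.

The two measured compounds share one core and differ only in the aromatic group attached to the carbon that carries the double bond to nitrogen. In a functional assay on PC-3 cells (Homo sapiens) for inhibition, read by sulforhodamine B assay, with a stated time of 48 h (a higher number here means a weaker inhibitor of growth, a lower number a stronger inhibitor of growth), compound 1 gives 5700 nM, while compound 2 gives 700 nM. Going by the values given here, the single step between them, an 8.1-fold lower number from compound 1 to compound 2 (0.91 log units; beyond the scatter), is the only comparison available. Among the compounds with values here, compound 2 therefore holds the lower of the two numbers in this assay, with compound 1 the only neighbour.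

Compound 3, `CC1=CC[C@H](C(C)(C)NC(=S)N/N=C/c2ccco2)CC1`, has not yet been measured. It differs from compound 2 by furan-2-yl in place of 2-chlorophenyl on a carbon with a double bond to nitrogen. Within the data shown here, the one measured step bears only partly on this change: it shows that the chloro substituent on the phenyl ring lowered the number, and compound 3 has neither that substituent nor the six-membered ring. Since the gain in compound 2 is tied to that chloro, its loss is expected to move the number back towards that of compound 1, so a step of a 4.3-fold higher number from compound 2 to compound 3 (0.63 log units; beyond the scatter) is expected. Compound 3 is estimated to give 3000 nM in this assay, within 900 nM to 10000 nM.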

Compound 3, concentration for total growth inhibition: 27200 nM
The estimate for compound 3 lay 9.1-fold (0.96 log units) below the measured number; measured number above the stated range.
By their numbers in this assay, from the lowest: compound 2; then compound 1; then compound 3.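

In this assay the aromatic group on the carbon with a double bond to nitrogen matters even without the chloro substituent. Replacing phenyl with furan-2-yl brings a 4.8-fold higher number from compound 1 to compound 3 (0.68 log units; beyond the scatter) and so shows that compound 3 does not simply return to the level of compound 1 once chloro is gone; the one-atom-for-ring view of the earlier pair is replaced by a clear effect of the ring itself. Replacing 2-chlorophenyl with furan-2-yl brings a 39-fold higher number from compound 2 to compound 3 (1.59 log units; beyond the scatter) and is the largest step among the three compounds, while nothing available explains why furan-2-yl gives the highest number of the three.

From the compounds shown here alone, it remains open whether chloro on the furan-2-yl ring would lower the number as it did on the phenyl ring. Going by these compounds, it also remains open how a methoxy group or an amine on the phenyl ring would compare with chloro, and whether any change away from this aromatic group, on the rest of the shared core, would shift the number at all.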